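From 3-chlorophenyl to 4-hydroxyphenyl on the shared core

A few compounds are considered here, and "the series" means these few. Any claim that something is new, unique, unknown or untested is made for them only; others in the source may bear on it.

Measured in a functional assay on A2780 cells (Homo sapiens) for antiproliferative activity, read by MTT assay, with a stated time of 48 h; a higher number here means a weaker inhibitor of growth, a lower number a stronger inhibitor of growth:
Compound 1 `COC(=O)N1N=C(c2ccc(OC)cc2)CC1c1cc(OC)c(OC)c(OC)c1`: 5000 nM
Compound 2 `COC(=O)N1N=C(c2cccc(C)c2)CC1c1cc(OC)c(OC)c(OC)c1`: 600 nM
Compound 3 `COC(=O)N1N=C(c2cccc(Cl)c2)CC1c1cc(OC)c(OC)c(OC)c1`: 1540 nM

Compound 3 holds the middle of these three numbers, with a 2.6-fold higher number from compound 2 to compound 3 (0.41 log units; beyond the scatter) on one side and a 3.2-fold lower number from compound 1 to compound 3 (0.51 log units; beyond the scatter) on the other. Compound 4 `COC(=O)N1N=C(c2ccc(O)cc2)CC1c1cc(OC)c(OC)c(OC)c1` has not yet been measured. It carries 4-hydroxyphenyl in place of 3-chlorophenyl on a carbon with a double bond to nitrogen.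

For the measured compounds named here, no measured step introduces this group, so the comparison is indirect. The closest measured group is the 4-methoxyphenyl of compound 1, which gives 5000 nM. Moving away from that group lowered the number in both measured cases, with an 8.3-fold lower number from compound 1 to compound 2 (0.92 log units; beyond the scatter) and a 3.2-fold lower number from compound 1 to compound 3 (0.51 log units; beyond the scatter). A modest rise from compound 3 is therefore expected in this assay, undoing much of that gain. The expected change is a 2.3-fold higher number from compound 3 to compound 4 (0.36 log units; beyond the scatter). For compound 4 the estimate is 3500 nM, with an expected range from 1200 nM to 10000 nM.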

Compound 4, concentration for 50% growth inhibition: 2520 nM
Estimate against measurement, compound 4: 1.4-fold (0.14 log units) above, and the stated range covers the measured number.
By their numbers in this assay, from the lowest: compound 2; then compounds 3, 4 and 1 (each within the scatter of the next, the first and the last beyond it).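

In this assay, putting 4-hydroxyphenyl in place of 3-chlorophenyl gives a 1.6-fold higher number from compound 3 to compound 4 (0.21 log units; within the scatter), so this exchange, which adds a hydrogen-bond donor and a hydrogen-bond acceptor to the group, leaves no readable difference. Hydrogen in place of methyl on the oxygen gives a 2.0-fold lower number from compound 1 to compound 4 (0.30 log units; within the scatter), so removing that methyl also leaves no readable difference at this position. For the compounds shown here, the 3-methylphenyl of compound 2 stands apart from the new group, with a 4.2-fold higher number from compound 2 to compound 4 (0.62 log units; beyond the scatter), the only new step that is beyond the scatter.

Nothing available bears on why these groups give these numbers. The compounds shown also leave open how an amine or a carboxylic acid in place of the hydroxyl would behave on the phenyl ring, and whether a hydroxyl at the 3-position would match the 3-methylphenyl of compound 2.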